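The source may report more compounds than this note shows. Statements on the series, on what has been measured and on what is new or still open speak of the compounds shown alone.

Compound 1 `O=C(Nc1cccc(-n2cc(-c3ccncc3)c(-c3cc(O)cc(Cl)c3)n2)c1)Nc1ccc(Cl)c(C(F)(F)F)c1` is a urea carrying a 3-chloro-5-hydroxyphenyl group on a shared core. Among the compounds with values here, in a functional assay on PC-3 cells (Homo sapiens) for inhibition, read by sulforhodamine B assay, with a stated time of 48 h (a lower number here means a stronger inhibitor, a higher number a weaker inhibitor), compound 1 gives 2100 nM, the higher of only two numbers recorded so far, a standing that carries little weight since the step of a 1.2-fold lower number from compound 1 to compound 2 (0.09 log units; within the scatter) lies within the scatter. That neighbour, compound 2 `O=C(Nc1cccc(-n2cc(-c3ccncc3)c(-c3cc(O)cc(Cl)c3)n2)c1)Nc1ccc(Cl)c(Cl)c1`, differs only in carrying chloro in place of trifluoromethyl on an aromatic carbon, and in this assay compound 2 gives 1690 nM.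

Compound 3 `COc1cc(Cl)cc(-c2nn(-c3cccc(NC(=O)Nc4ccc(Cl)c(C(F)(F)F)c4)c3)cc2-c2ccncc2)c1` leaves the trifluoromethyl end of compound 1 untouched and alters the other end instead: methyl in place of hydrogen on an oxygen on an aromatic ring, so hydroxy becomes methoxy and 3-chloro-5-hydroxyphenyl becomes 3-chloro-5-methoxyphenyl. Within the data shown here, no measured step touches this part of the molecule; the one step available concerns a different ring and says nothing about the hydroxy. The expectation therefore rests on the structural change alone, and a modest move toward a higher number, a 1.7-fold higher number from compound 1 to compound 3 (0.22 log units; within the scatter), is estimated with wide uncertainty. Compound 3 is expected to give about 3500 nM in this assay, most likely between 1200 nM and 10000 nM.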

Compound 3, half-maximal inhibitory concentration: 340 nM
For compound 3 the middle estimate is 10-fold (1.01 log units) above the measured one; measured number below the stated range.
By their numbers in this assay, from the lowest: compound 3; then compounds 2 and 1 (each within the scatter of the next).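

In this assay, replacing the hydrogen on this oxygen with methyl gives a 6.2-fold lower number from compound 1 to compound 3 (0.79 log units; beyond the scatter) and is the only step shown at this position, while the step at the other end of the molecule, from trifluoromethyl to chloro, stayed within the scatter. The position is therefore not indifferent to what sits on the oxygen, and with the trifluoromethyl end in place, the hydrogen of the hydroxy is not needed for a number this low, since the methoxy compound has the lower one. No measurement given here bears on why the number fell, so this single step records the size of the change but not its cause.

It remains open whether methoxy would lower the number to the same extent with the chloro end of compound 2, since the methoxy group is shown only with the trifluoromethyl end. One step also cannot show whether a longer chain on the oxygen, such as ethoxy, or an amine in place of the methoxy would continue the change or reverse it.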